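A few compounds are considered here, and "the series" means these few. Any claim that something is new, unique, unknown or untested is made for them only; others in the source may bear on it.

Measured compounds:
- compound 1, `c1cncc(-c2cncc(N3CCCNCC3)c2)c1`: 2.8 nM
- compound 2, `CCSc1ccc(N2CCCNCC2)cn1`: 170 nM

In an assay on cell membranes for binding affinity to Neuronal acetylcholine receptor; alpha4/beta2 (Rattus norvegicus), read by radioligand binding (on this read-out higher numbers stand for weaker inhibition and lower numbers for stronger inhibition), compound 1 gives 2.8 nM, while compound 2 gives 170 nM. Going by the values given here, of the two numbers known in this assay, compound 2 therefore holds the higher one, and the gap between the two values is wide rather than a matter of scatter. Among the compounds with values here, no step between measured compounds has been worked out here, so the effect of any single change on the shared core remains undetermined from direct comparison.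

Compound 3, `COc1ccc(N2CCCNCC2)cn1`, has not yet been measured. It differs from compound 2 in one place only: methoxy in place of ethylsulfanyl on an aromatic carbon. Both substituents are small, uncharged and carry a single acceptor, and the position on the ring is unchanged. Within the data shown here, with no measured pair to lean on, a modest step is expected from compound 2 to compound 3 in this assay, a 2.4-fold lower number from compound 2 to compound 3 (0.39 log units; beyond the scatter), towards a somewhat lower number, though the uncertainty spans both directions. Compound 3 is estimated at 70 nM, with a plausible range from 15 nM to 350 nM.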

Compound 3, half-maximal inhibitory concentration: 170 nM
Beside the measured number, compound 3's estimate is 2.4-fold (0.39 log units) below it; the range from low to high includes it.
By their numbers in this assay, from the lowest: compound 1; then compounds 2 and 3 (each within the scatter of the next).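

In this assay, going by these compounds alone, the first single-place comparison shows that methoxy in place of ethylsulfanyl gives no change at the digits printed from compound 2 to compound 3 (within the scatter) on this read-out. At this position, on an aromatic carbon next to the ring nitrogen and para to a group of 7 heavy atoms, the assay therefore does not separate these two groups, although one has 3 heavy atoms including sulfur and the other has 2 including oxygen. The finding is limited to this one exchange between two groups with no ring, no net charge, no hydrogen-bond donor and 1 hydrogen-bond acceptor each, so it does not show that the position accepts substituents in general.

Going by these compounds, it remains open whether the number would hold with a primary amine, a carboxylic acid, a longer chain such as butoxy or a ring such as phenyl at the same place. Nothing available here explains why the two groups give matching numbers, and the reason for that match stays unknown.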